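Swapping the phenol for a pyrrolidine in compound 1

The compounds below may be only part of what the source reports. "The series", "measured", "known", "first", "only" and "open" are said of these compounds alone.

Measured compounds:
compound 1, `Oc1ccc(CNc2cc(C(F)(F)F)cc3[nH]ncc23)cc1`, 75%
compound 2, `O=[N+]([O-])c1ccc(CNc2cc(C(F)(F)F)cc3[nH]ncc23)cc1`, 47%
compound 3, `O=[N+]([O-])c1cccc(CNc2cc(C(F)(F)F)cc3[nH]ncc23)c1`, 60%

In an assay for inhibition of Tryptophan 2,3-dioxygenase (Homo sapiens), with stated times of 10 min and 60 min, tested at 10 uM (a lower number here means a weaker effect, a higher number a stronger effect of the compound at the concentration tested), compound 1 gives the highest of the three numbers; compound 3 sits below it and compound 2 lowest. For the measured compounds named here, the one measured step, a number 28 percentage points lower from compound 1 to compound 2 (beyond the scatter), shows that altering the phenol ring weakens the effect in this assay. Compound 4, `FC(F)(F)c1cc(NC[C@H]2CCCN2)c2cn[nH]c2c1`, goes further: pyrrolidin-2-yl in place of 4-hydroxyphenyl on a saturated chain carbon bound to a nitrogen on an aromatic ring. Going by the values given here, no measured step covers replacement of the whole aromatic ring by a saturated one, so only the direction of the existing step offers guidance. A drop beyond the scatter is expected, a number 35 percentage points lower from compound 1 to compound 4 (beyond the scatter), and compound 4 is estimated at 40%, in the range 15% to 65%.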

Compound 4, a percentage reported as inhibition, at one concentration (the size of the read-out at that concentration, not a potency): 55%
Estimate against measurement, compound 4: 15 percentage points below; the measured number falls inside the stated range.
By their numbers in this assay, from the lowest: compounds 2, 4 and 3 (each within the scatter of the next, the first and the last beyond it); then compound 1.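

In this assay, pyrrolidin-2-yl in place of 4-hydroxyphenyl gives a number 20 percentage points lower from compound 1 to compound 4 (beyond the scatter) and so costs part of the effect. The earlier compounds shown here all carry an aromatic ring at this place, whereas compound 4 stands at 55% with a non-aromatic ring there, so an aromatic ring is not needed for some effect. No measurement at hand explains this step.

On these data alone, whether the loss follows from removing the aromatic ring or from adding the ring nitrogen stays open. The role of the defined stereocentre is also unsettled; the mirror-image pyrrolidine, a piperidine or an open-chain amine would help separate these.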